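The source may report more compounds than this note shows. Statements on the series, on what has been measured and on what is new or still open speak of the compounds shown alone.

Compound 1 `N#CC1=C(N)OC(c2c[nH]c3ccccc23)=C(C#N)C1c1ccccc1F` was reported in a functional assay, tested at 100 ug/mL (a lower number here means a weaker effect, a higher number a stronger effect of the compound at the concentration tested), as "not active" (no number reported) with no number. Compound 2 `COc1ccc(C2C(C#N)=C(N)OC(c3c[nH]c4ccccc34)=C2C#N)cc1OC` gives 19.1% in this assay. Compound 3 `Cc1ccccc1C1C(C#N)=C(N)OC(c2c[nH]c3ccccc23)=C1C#N` gives 17.2% in this assay.

Compound 3 thus holds the lower of the two numbers, with compound 2 nearest; the step of a number 1.9 percentage points lower from compound 2 to compound 3 (within the scatter) lies within the scatter. Compound 4 `COc1ccc(C2C(C#N)=C(N)OC(c3c[nH]c4ccccc34)=C2C#N)cc1` differs from compound 3 by 4-methoxyphenyl in place of 2-methylphenyl on a saturated ring carbon. Within the data shown here, the single measured step that bears on a change of the aryl group at this place is a number 1.9 percentage points lower from compound 2 to compound 3 (within the scatter), where a 3,4-dimethoxyphenyl and a 2-methylphenyl gave numbers within the scatter of each other. On that basis no step beyond the scatter is expected for compound 4, a number 1.8 percentage points higher from compound 3 to compound 4 (within the scatter). Compound 4 is therefore estimated at 19%, with a range from 8% to 32%.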

Compound 4, a percentage reported as activity, at one concentration (the size of the read-out at that concentration, not a potency): 20%
Compound 4: the middle estimate sits 1 percentage points below what was measured; the range from low to high includes it.
By their numbers in this assay, from the lowest: compounds 3, 2 and 4 (each within the scatter of the next).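

In this assay the read-out does not separate 4-methoxyphenyl from 2-methylphenyl on this saturated ring carbon, with a number 2.8 percentage points higher from compound 3 to compound 4 (within the scatter) as the step. Removing one methoxy from the aromatic ring also makes no difference beyond the scatter, with a number 0.9 percentage points higher from compound 2 to compound 4 (within the scatter) as the step, so the three aryl groups with numbers cannot be told apart here. No measured evidence offers an explanation for this.

On these data alone, whether a group other than a substituted phenyl, such as an amine or a carboxylic acid, would change the read-out at this carbon stays open. Compound 1, reported without a number, cannot be placed among the others.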